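The source may hold more compounds than are shown below. What is called first, only, known or untested is meant among the compounds shown, and "the series" means these compounds.

Going by the values given here, compound 1, `CCCCCCOc1cccc(O)c1C(=O)/C=C/c1ccc(O)cc1`, stands only at a limit on the numbers so far. In a functional assay on HCT-15 cells (Homo sapiens) for antiproliferative activity, read by sulforhodamine B assay (on this read-out lower numbers stand for stronger inhibition of growth and higher numbers for weaker inhibition of growth), compound 1 gives > 30000 nM, a limit of the assay and not a number. Compound 2, `CC(C)=CCOc1cccc(O)c1C(=O)/C=C/c1ccc(O)cc1`, in this assay gives > 30000 nM, likewise a limit. Among the compounds with values here, the one measured step, a step that the two limits leave unreadable from compound 1 to compound 2, cannot be read, since (the limit of > 30000 nM in this assay, at which 2 of the 2 values shown sit). Compound 3, `O=C(/C=C/c1ccc(O)cc1)c1c(O)cccc1OCc1ccccc1`, differs from compound 1 by phenyl in place of pentyl on a saturated chain carbon bound to an oxygen on an aromatic ring. Within the data shown here, no measured step bears on this change, so no step beyond the scatter is expected. Compound 3 is expected to give 40000 nM, between 10000 nM and 120000 nM, most probably again as a limit. The expected step that the limit leaves unreadable from compound 1 to compound 3 is thus taken as none beyond the scatter.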

Compound 3, concentration for 50% growth inhibition: > 30000 nM
Compound 3 ended at the assay's limit; the forecaster's own chance of this, stated with the estimate: 75%; the middle value does not contradict the limit.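

No step among compound 1, compound 2 and compound 3 can be read in this assay: the limit of > 30000 nM in this assay, at which 3 of the 3 values shown sit.

The compounds shown leave open whether pentyl, 2-methylprop-1-en-1-yl and phenyl differ at all in their effect on growth inhibition.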